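Changing the aryl group on the amine nitrogen of compound 3

This account rests on a few compounds, and the source may have more. Where it says the series, first, only, none or still open, it means among the compounds named here.

Of the compounds shown here, three share one core and have been tested in a functional assay on NCI-H520 cells (Homo sapiens) for inhibition, read by MTT assay, with a stated time of 48 h, tested at 10 uM; on this read-out higher numbers stand for more inhibition at the one concentration tested (going by the name of the read-out) and lower numbers for less inhibition. Compound 1 `COc1cc(Br)ccc1Nc1cc(NC(=O)Nc2c(Cl)cccc2Cl)ncn1` gives 29.1%. Compound 2 `COc1cc(NC(=O)Nc2cc(Nc3cccc(C(C)(C)C)c3)ncn2)cc(OC)c1` gives 13.1%. Compound 3 `COc1cc(NC(=O)Nc2cc(Nc3ccc(OC)c(I)c3)ncn2)cc(OC)c1` gives 46.5%, the highest of the three, beyond the scatter above both others.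

Compound 4 `COc1cc(NC(=O)Nc2cc(Nc3ccc(Br)cc3OC)ncn2)cc(OC)c1` has not yet been measured. It differs from compound 3 in one place: 4-bromo-2-methoxyphenyl in place of 3-iodo-4-methoxyphenyl on a nitrogen on an aromatic ring. Among the measured compounds shown here, the one measured step at this same position is a number 33.4 percentage points higher from compound 2 to compound 3 (beyond the scatter), a large change, which shows that the aryl group on this nitrogen matters a great deal in this assay. Compound 1 carries the same 4-bromo-2-methoxyphenyl that enters in compound 4, though with a different urea aryl, and its value stands well below that of compound 3. Taken together, a drop from compound 3 to compound 4 is expected, estimated as a number 16.5 percentage points lower from compound 3 to compound 4 (beyond the scatter). Compound 4 is therefore expected to give about 30%, within a range of 12% to 48%.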

Compound 4, a percentage reported as inhibition, at one concentration (the size of the read-out at that concentration, not a potency): 36.1%
Beside the measured number, compound 4's estimate is 6.1 percentage points below it; measured number inside the range.
By their numbers in this assay, from the lowest: compound 2; then compounds 1 and 4 (each within the scatter of the next); then compound 3.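

In this assay, replacing one halogen-and-methoxy aryl group with another on this nitrogen gives a modest loss (a number 10.4 percentage points lower from compound 3 to compound 4 (beyond the scatter)), yet a clear gain remains over the 3-(tert-butyl)phenyl group (a number 23 percentage points higher from compound 2 to compound 4 (beyond the scatter)). The other end of the molecule can now be read as well: with 4-bromo-2-methoxyphenyl held fixed, 3,5-dimethoxyphenyl in place of 2,6-dichlorophenyl on the amide-type nitrogen gives a step within the scatter (a number 7 percentage points higher from compound 1 to compound 4 (within the scatter)), so these two groups cannot be told apart here. No supporting data explain these differences.

Because the halogen and the positions of both substituents change together from compound 3 to compound 4, their separate contributions remain unresolved. On these data alone, it also remains open whether the number in this assay would be higher, lower or level with an unsubstituted phenyl, or a phenyl carrying a carboxylic acid or a dimethylamino group, on this nitrogen.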